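This account rests on a few compounds, and the source may have more. Where it says the series, first, only, none or still open, it means among the compounds named here.

Compound 1 `COc1ccc(C(=O)NNC(=O)c2ccc3[nH]c(-c4ccc([N+](=O)[O-])o4)nc3c2)cc1OC` is the starting point of this account. In a functional assay on M14 cells (Homo sapiens) for inhibition, read by sulforhodamine B assay, with a stated time of 48 h (a lower number here means a stronger inhibitor of growth, a higher number a weaker inhibitor of growth), compound 1 gives 15.6 ug/mL. Two close relatives sit at the same level: compound 2 `COc1cccc(C(=O)NNC(=O)c2ccc3[nH]c(-c4ccc([N+](=O)[O-])s4)nc3c2)c1` gives 15.6 ug/mL in this assay, and compound 3 `COc1cc(C(=O)NNC(=O)c2ccc3[nH]c(-c4ccc([N+](=O)[O-])o4)nc3c2)cc(OC)c1OC` gives 15.6 ug/mL. Compound 1 stands level with compound 2 and compound 3 at the digits shown, the nearest being compound 2 and the furthest compound 3, both within the scatter. Among the measured compounds shown here, the one single-point step that has been measured, no change at the digits printed from compound 1 to compound 3 (within the scatter), adds a methoxy on an aromatic carbon and moves nothing beyond the scatter.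

The unmeasured compound 4 `O=CNNC(=O)c1ccc2[nH]c(-c3ccc([N+](=O)[O-])o3)nc2c1` differs from compound 1 in a larger way: hydrogen in place of 3,4-dimethoxyphenyl on a carbonyl carbon. The whole 3,4-dimethoxyphenyl group, one six-membered aromatic ring with its two acceptors, is taken away from the carbonyl carbon next to the amide-type nitrogen. For the measured compounds named here, no measured step removes a ring of this size, so the step of no change at the digits printed from compound 1 to compound 3 (within the scatter), which only adds a methoxy to that same ring, bears on it weakly and gives no direction. Losing the whole ring is expected to cost something, so a step toward weaker growth inhibition is estimated, a 2.2-fold higher number from compound 1 to compound 4 (0.35 log units; beyond the scatter), with wide uncertainty. Compound 4 is therefore expected to give about 35 ug/mL, between 12 ug/mL and 110 ug/mL.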

Compound 4, concentration for 50% growth inhibition: 31.3 ug/mL
For compound 4 the middle estimate is 1.1-fold (0.05 log units) above the measured one; the range from low to high includes it.
By their numbers in this assay, from the lowest: compounds 1, 2, 3 and 4 (each within the scatter of the next).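

In this assay, the step of a 2.0-fold higher number from compound 1 to compound 4 (0.30 log units; within the scatter) takes the whole 3,4-dimethoxyphenyl group, with its six-membered aromatic ring, off the carbonyl carbon and leaves only hydrogen there. The earlier compounds shown here had tested this place only by adding a methoxy to that ring, whereas compound 4 shows that, on this carbonyl carbon whose other neighbour is the amide-type nitrogen, even the loss of the entire ring leaves the read-out within the scatter, so a group of this size is not required for a value of this order in this assay. Nothing available here bears on why the read-out holds, and no explanation can be offered for it.

The compounds shown leave open whether a different group on this carbonyl carbon, such as a primary amine, a carboxylic acid or a longer alkyl chain, would move the number beyond the scatter in either direction. They also leave open whether replacing the aromatic ring with hydrogen would read the same on the core of compound 2.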